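The source may report more compounds than this note shows. Statements on the series, on what has been measured and on what is new or still open speak of the compounds shown alone.

Measured so far in a functional assay on HeLa cells (Homo sapiens) for cytotoxicity, read by sulforhodamine B assay; on this read-out lower numbers stand for stronger inhibition and higher numbers for weaker inhibition:
- compound 1, `Cc1ccc(S(=O)(=O)NC(C)C2=CC(=O)c3c(O)ccc(O)c3C2=O)cc1`, gives 5340 nM
- compound 2, `COc1ccc(S(=O)(=O)NC(C)C2=CC(=O)c3c(O)ccc(O)c3C2=O)c(OC)c1`, gives 19500 nM
- compound 3, `CC(NS(=O)(=O)c1ccc(Cl)cc1)C1=CC(=O)c2c(O)ccc(O)c2C1=O`, gives 810 nM

Compound 3 holds the lowest number of the three. Among the compounds with values here, the step of a 6.6-fold lower number from compound 1 to compound 3 (0.82 log units; beyond the scatter) and the step of a 24-fold lower number from compound 2 to compound 3 (1.38 log units; beyond the scatter) both run beyond the scatter, so compound 3 is the most potent compound measured so far. Compound 2 in turn sits above compound 1, as the step of a 3.7-fold higher number from compound 1 to compound 2 (0.56 log units; beyond the scatter) shows.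

Compound 4, `CC(NS(=O)(=O)c1cccc(Br)c1)C1=CC(=O)c2c(O)ccc(O)c2C1=O`, is not yet measured. It differs from compound 3 by 3-bromophenyl in place of 4-chlorophenyl on a sulfonyl sulfur.

The measured steps touch this change only loosely. The step of a 6.6-fold lower number from compound 1 to compound 3 (0.82 log units; beyond the scatter) swaps a methyl for a chloro on an aromatic carbon; the step of a 24-fold lower number from compound 2 to compound 3 (1.38 log units; beyond the scatter) swaps a 2,4-dimethoxyphenyl for a 4-chlorophenyl. Within the data shown here, no measured compound carries a 3-bromophenyl, and no measured pair compares two aryl groups of this kind. Both steps do show that the group on the sulfonyl sulfur moves this assay by more than the scatter, so the change cannot be taken as neutral. Without a closer precedent, the expected step of a 1.5-fold higher number from compound 3 to compound 4 (0.17 log units; within the scatter) is small, somewhat toward a higher number, with wide uncertainty. The estimate for compound 4 in this assay is 1200 nM, with a range from 400 nM to 4000 nM.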

Compound 4, half-maximal inhibitory concentration: 6350 nM
Compound 4: middle estimate off by 5.3-fold (0.72 log units), on the low side, and the stated range ends below it.
By their numbers in this assay, from the lowest: compound 3; then compounds 1 and 4 (each within the scatter of the next); then compound 2.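

In this assay, the group on the sulfonyl sulfur separates even two halogen-bearing phenyl groups: 3-bromophenyl in place of 4-chlorophenyl gives a clear loss (a 7.8-fold higher number from compound 3 to compound 4 (0.89 log units; beyond the scatter)), so a halogen on the phenyl ring does not by itself bring the low number of compound 3. Against the 4-methylphenyl group, 3-bromophenyl makes no difference that can be read (a 1.2-fold higher number from compound 1 to compound 4 (0.08 log units; within the scatter)). Against the 2,4-dimethoxyphenyl group, it still gives a lower number (a 3.1-fold lower number from compound 2 to compound 4 (0.49 log units; beyond the scatter)), so compound 2 remains the weakest of the four and compound 3 the strongest.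

Nothing at hand accounts for the gap between the two halogen-bearing groups. A 4-bromophenyl or a 3-chlorophenyl on the sulfonyl sulfur would separate the two changes combined in this step, the identity of the halogen and its place on the ring.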